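The source may hold more compounds than are shown below. What is called first, only, known or untested is meant among the compounds shown, and "the series" means these compounds.

Compound 1 `COC(=O)c1ccc2ccc(C(=O)N(C)C)c-2cc1`: > 64 ug/mL (a limit)
Compound 2 `COC(=O)c1ccc2ccc(C(=O)c3ccccc3)c-2cc1`: < 1 ug/mL (a limit)
Compound 3 `O=C(NCc1cccnc1)c1ccc2ccc(C(=O)c3ccccc3)c-2cc1`: < 1 ug/mL (a limit)

In a physicochemical assay for solubility, with a stated time of 24 h, at pH 6.8 (on this read-out lower numbers stand for lower solubility and higher numbers for higher solubility), compound 2 gives < 1 ug/mL, which is a limit and not a number. Compound 4 `COC(=O)c1ccc2ccc(C(=O)Nc3ccccc3)c-2cc1` differs from it by one change: anilino in place of phenyl on a carbonyl carbon. Of the measured steps, an at least 64-fold lower number from compound 1 to compound 2 (1.80 log units; beyond the scatter) concerns a carbonyl carbon with phenyl entering, so it bears most directly. The other, a step that the two limits leave unreadable from compound 2 to compound 3, gives no size to work with. Anilino still holds a six-membered aromatic ring of carbon only, so compound 4 is expected to recover only a small part of an at least 64-fold lower number from compound 1 to compound 2 (1.80 log units; beyond the scatter), and to rise slightly in this assay. The estimated step is an at least 2.0-fold higher number from compound 2 to compound 4 (0.30 log units; that floor lies within the scatter). The estimated value of compound 4 is 2 ug/mL, with an expected range of 0.5 ug/mL to 10 ug/mL.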

Compound 4, solubility: < 1 ug/mL
Compound 4 ended at the assay's limit; the forecaster's own chance of this, stated with the estimate: 45%; middle value at least 2.0-fold (0.30 log units) from the limit.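

In this assay, among the compounds shown here, the result gives the first reading for a nitrogen on this carbonyl carbon other than dimethylamino, and an at least 64-fold lower number from compound 1 to compound 4 (1.80 log units; beyond the scatter) shows that such a nitrogen alone does not preserve the reading of compound 1. With anilino in place of phenyl, the step from compound 2 to compound 4 cannot be read, since both values are limits: the limit of < 1 ug/mL in this assay, at which 3 of the 4 values shown sit. On these data alone, whether morpholine or methylamino on this carbonyl carbon would keep the reading of compound 1 stays open, as does how far compound 2 and compound 4 lie beyond their limits.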